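Cytotoxicity notes: from compound 3 to compound 4

The compounds below may be only part of what the source reports. "The series", "measured", "known", "first", "only" and "open" are said of these compounds alone.

In a toxicity assay on MT4 cells (Homo sapiens) for cytotoxicity, read by MTT assay (a lower number here means that less compound is tolerated, a higher number that more compound is tolerated), compound 1 `Cc1cc(-c2ccccc2)cc(C)c1Oc1cc(N)nc(Nc2ccc(C#N)cc2)n1` gives 25600 nM and compound 2 `Cc1cc(-c2ccccc2Cl)cc(C)c1Oc1cc(N)nc(Nc2ccc(C#N)cc2)n1` gives 25100 nM with a 1.0-fold lower number from compound 1 to compound 2 (0.01 log units; within the scatter) as their step. Compound 3 `Cc1ccc(-c2cc(C)c(Oc3cc(N)nc(Nc4ccc(C#N)cc4)n3)c(C)c2)cc1` at 10000 nM is the lowest of the three, with a 2.6-fold lower number from compound 1 to compound 3 (0.41 log units; beyond the scatter) and a 2.5-fold lower number from compound 2 to compound 3 (0.40 log units; beyond the scatter) as its steps. Compound 4 `COc1ccccc1-c1cc(C)c(Oc2cc(N)nc(Nc3ccc(C#N)cc3)n2)c(C)c1` has 2-methoxyphenyl in place of 4-methylphenyl on an aromatic carbon and awaits measurement. The measured group named most like 2-methoxyphenyl is 2-chlorophenyl, so the closest guide is a 2.5-fold lower number from compound 2 to compound 3 (0.40 log units; beyond the scatter) read in reverse, which suggests a modest rise in this assay for this exchange. The expected step is a 2.0-fold higher number from compound 3 to compound 4 (0.30 log units; within the scatter) on this reading. For compound 4 the estimate is 20000 nM with an expected range from 9000 nM to 45000 nM in this read-out.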

Compound 4, half-maximal cytotoxic concentration: 21800 nM
Beside the measured number, compound 4's estimate is 1.1-fold (0.04 log units) below it, and the stated range covers the measured number.
By their numbers in this assay, from the lowest: compound 3; then compounds 4, 2 and 1 (each within the scatter of the next).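

In this assay the exchange of 4-methylphenyl for 2-methoxyphenyl gives a 2.2-fold higher number from compound 3 to compound 4 (0.34 log units; beyond the scatter) and so moves away from the lowest number of the series. Methoxy reads like the groups it can be set against at the same place on the phenyl ring, with a 1.2-fold lower number from compound 2 to compound 4 (0.06 log units; within the scatter) against chloro and a 1.2-fold lower number from compound 1 to compound 4 (0.07 log units; within the scatter) against hydrogen, which leaves compound 3 alone apart from the other three. The data shown offer no evidence on why the 4-methylphenyl compound stands apart. Still open, from the compounds shown here alone, is whether 4-methoxyphenyl or 4-chlorophenyl would follow compound 3, and what an amine or a carboxylic acid on this phenyl ring would do.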